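The compounds below may be only part of what the source reports. "The series", "measured", "known", "first", "only" and "open" are said of these compounds alone.

Working notes on the hydroxy-amide series, metabolic stability.

Three members of the series have numbers in an ADME assay on liver for metabolic stability, with Liver microsome (Homo sapiens) as the target, using microsomes; on this read-out higher numbers stand for fast clearance and lower numbers for slow clearance. Compound 1 `O=C(N[C@H]1CCCC[C@@H]1O)c1cn(Cc2ccc(-c3cncnc3)cc2)c2cccnc12` gives 104 mL/min/kg. Compound 2 `Cn1ccc(-c2ccc(Cn3cc(C(=O)N[C@H]4CCCC[C@@H]4O)c4ncccc43)cc2)n1` gives 47 mL/min/kg and stands second highest of the three, with compound 1 the nearer neighbour and compound 3 the further one. Compound 3 `Cn1ccc(-c2ccc(Cn3cc(C(=O)N[C@H]4CCOC[C@@H]4O)c4ncccc43)cc2)n1` gives 10.6 mL/min/kg.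

Two single-point steps are known. Exchanging the aryl substituent gave a 2.2-fold lower number from compound 1 to compound 2 (0.34 log units; beyond the scatter). Exchanging the amide-side ring gave a 4.4-fold lower number from compound 2 to compound 3 (0.65 log units; beyond the scatter).

Compound 4 `N#Cc1ccc(Cn2cc(C(=O)N[C@H]3CCCC[C@@H]3O)c3ncccc32)cc1` has not been measured. Relative to compound 2 the change is cyano in place of 1-methyl-1H-pyrazol-3-yl on an aromatic carbon. Among the compounds with values here, the only measured step touching this aromatic carbon is the one from compound 1 to compound 2, and it swapped one six-membered heteroaromatic ring for a five-membered one, not for a small non-ring group; the series holds no step of that kind. The step from compound 2 to compound 3, at the amide-type nitrogen, does not bear on the change. The expectation for compound 4 in this assay is therefore no step beyond the scatter from compound 2, that is a 1.1-fold higher number from compound 2 to compound 4 (0.03 log units; within the scatter). The estimate for compound 4 is 50 mL/min/kg, with a range from 22 mL/min/kg to 115 mL/min/kg.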

Compound 4, clearance: 18 mL/min/kg
For compound 4 the middle estimate is 2.8-fold (0.44 log units) above the measured one, and the stated range ends above it.
By their numbers in this assay, from the lowest: compounds 3 and 4 (each within the scatter of the next); then compound 2; then compound 1.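

Within the data shown here, at this aromatic carbon, para to a large group, the earlier compounds showed only one aromatic ring exchanged for another; in this assay the non-ring cyano group now gives a 2.6-fold lower number from compound 2 to compound 4 (0.42 log units; beyond the scatter) and, measured against the pyrimidin-5-yl group, a 5.8-fold lower number from compound 1 to compound 4 (0.76 log units; beyond the scatter). Among the three compounds that carry the 2-hydroxycyclohexyl group on the amide nitrogen, the read-out therefore responds to this position beyond the scatter at each listed step, and an aromatic ring on this carbon is not needed for the lowest number of these three, compound 4 at 18 mL/min/kg. No measurement in hand accounts for the size of this step, so the result stands as an observation about these groups only.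

The compounds shown leave open whether the result belongs to cyano itself or extends to other small non-ring groups on this carbon, such as an amine, a carboxylic acid or a longer chain ending in a nitrile. They also leave open whether cyano and the 3-hydroxyoxan-4-yl group, which have each been seen only separately, would combine in one compound to give a further step in this assay.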